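The source may report more compounds than this note shows. Statements on the series, on what has been measured and on what is new or still open speak of the compounds shown alone.

Working notes on the series in a physicochemical assay for solubility, in phosphate buffer, measured as kinetic solubility, at pH 7.4; a lower number here means a less soluble compound, a higher number a more soluble compound. Compound 1 `Cc1cccc(-c2nc(CN3CCC(C(=O)NCCCN4C[C@H](C)C[C@H](C)C4)CC3)c(C)o2)c1` gives > 69 ug/mL, which is a limit of the assay and not a number. Compound 2 `COc1cccc(Cl)c1-c1nc(CN2CCC(C(=O)NCCCN3C[C@H](C)C[C@H](C)C3)CC2)c(C)o1` gives > 76 ug/mL, likewise only a limit. For the measured compounds named here, the one measured step that bears on this position is a step that the two limits leave unreadable from compound 1 to compound 2, so it offers no size and no direction to carry forward.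

Compound 3 `CCc1ccccc1-c1nc(CN2CCC(C(=O)NCCCN3C[C@H](C)C[C@H](C)C3)CC2)c(C)o1` carries 2-ethylphenyl in place of 2-chloro-6-methoxyphenyl on an aromatic carbon of the shared core: 2-ethylphenyl in place of 2-chloro-6-methoxyphenyl on an aromatic carbon. With no readable step, no change beyond the scatter is expected in this assay, and another report as a limit is likely. The expected step is an at least 1.0-fold lower number from compound 2 to compound 3 (0.03 log units; that floor lies within the scatter). Compound 3 is estimated at 70 ug/mL, with an expected range from 30 ug/mL to 100 ug/mL.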

Compound 3, solubility: 55.9 ug/mL
For compound 3 the middle estimate is 1.3-fold (0.10 log units) above the measured one, and the stated range covers the measured number.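

In this assay, for the compounds shown here, compound 3 gives the first reading at this position that is a number and not a limit, and 2-ethylphenyl in place of 2-chloro-6-methoxyphenyl yields an at least 1.3-fold lower number from compound 2 to compound 3 (0.13 log units; that floor lies within the scatter). Against 3-methylphenyl, the same group yields an at least 1.2-fold lower number from compound 1 to compound 3 (0.09 log units; that floor lies within the scatter). Both steps are only floors, and their true size stays unknown, because each starts from a limit of the assay and not a number: the limit of > 69 ug/mL in this assay, at which 1 of the 3 values shown sits, and the limit of > 76 ug/mL in this assay, at which 1 of the 3 values shown sits.

No order among 2-ethylphenyl, 2-chloro-6-methoxyphenyl and 3-methylphenyl can be drawn from these three compounds. Also open, on these data alone, is what reading a phenyl group carrying an amine or a carboxylic acid would give at this position.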